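A few compounds are considered here, and "the series" means these few. Any claim that something is new, unique, unknown or untested is made for them only; others in the source may bear on it.

Within the data shown here, compound 2 `CCOC(=O)c1oc2ccc(NS(=O)(=O)c3ccccc3Cl)cc2c1C` is one of the two measured members of the shared core, the other being compound 1 `CCOC(=O)c1oc2ccc(NS(=O)(=O)c3ccccc3C)cc2c1C`. In a functional assay on MCF7 cells (Homo sapiens) for antiproliferative activity, read by MTT assay, with a stated time of 72 h (on this read-out higher numbers stand for weaker inhibition and lower numbers for stronger inhibition), compound 1 gives 105000 nM. In this assay compound 2 reaches only the limit of the assay, > 200000 nM, so where it stands is a floor rather than a number, as the limit of > 200000 nM in this assay, at which 1 of the 2 values shown sits, shows. Among the measured compounds shown here, the single measured step, an at least 1.9-fold higher number from compound 1 to compound 2 (0.27 log units; that floor lies within the scatter), is therefore itself a floor and lies within the usual scatter.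

Compound 3 `CCOC(=O)c1oc2ccc(NS(=O)(=O)c3ccc(Br)cc3)cc2c1C` has not yet been measured. It differs from compound 2 by 4-bromophenyl in place of 2-chlorophenyl on a sulfonyl sulfur. For the measured compounds named here, no measured step changes the whole aryl group on the sulfonyl sulfur; the only step available, an at least 1.9-fold higher number from compound 1 to compound 2 (0.27 log units; that floor lies within the scatter), swaps one substituent for another on an aromatic carbon and gives no direction beyond the scatter. The expectation for compound 3 in this assay is accordingly no step beyond the scatter, an at least 1.3-fold lower number from compound 2 to compound 3 (0.12 log units; that floor lies within the scatter). Compound 3 is estimated at 150000 nM, within 60000 nM to 400000 nM, with a substantial chance that only a limit is reported again.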

Compound 3, half-maximal inhibitory concentration: 56500 nM
Beside the measured number, compound 3's estimate is 2.7-fold (0.42 log units) above it; measured number below the stated range.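

Among these compounds, on the sulfonyl sulfur, exchanging the whole aryl group can move the read-out beyond the scatter, which the substituent swap between the earlier compounds did not show: in this assay, 4-bromophenyl in place of 2-chlorophenyl gives an at least 3.5-fold lower number from compound 2 to compound 3 (0.54 log units; beyond the scatter). Against the 2-methylphenyl member, the same 4-bromophenyl gives a 1.9-fold lower number from compound 1 to compound 3 (0.27 log units; within the scatter), so the separation seen from the 2-chlorophenyl member does not carry over to this comparison. The larger step is only a floor and its true size remains unknown, since compound 2 carries a limit and not a number: the limit of > 200000 nM in this assay, at which 1 of the 3 values shown sits.

The change from 2-chlorophenyl to 4-bromophenyl alters both the halogen and its place on the ring at once, and the compounds shown do not separate these two changes. On these data alone, it also remains open how a plain phenyl group or an aminophenyl group on the sulfonyl sulfur would read in this assay, and whether any such group would move the number beyond the scatter relative to compound 3.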